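Methyl replaces methoxy on a compound at the limit

The source may report more compounds than this note shows. Statements on the series, on what has been measured and on what is new or still open speak of the compounds shown alone.

In a toxicity assay on SW480 cells (Homo sapiens) for cytotoxicity, read by MTT assay, with a stated time of 3 h (a higher number here means a weaker inhibitor, a lower number a stronger inhibitor), compound 1 (`COc1ccc2c(c1)CCc1c(-c3ccccc3)c3n(c1-2)[B-](F)(F)[N+]1=C(c2ccc(C)cc2)C(Br)=C(c2ccccc2)C1=N3`) gives > 50000 nM as a limit and not a number. Compound 2 (`COc1ccc(C2=[N+]3C(=Nc4c(-c5ccccc5)c5c(n4[B-]3(F)F)-c3ccc(OC)cc3CC5)C(c3ccccc3)=C2I)cc1`) also stands at a limit and not a number, with > 50000 nM as its entry. The whole picture so far is the limit of > 50000 nM in this assay, at which 2 of the 2 values shown sit, and nothing finer. Compound 3 (`COc1ccc2c(c1)CCc1c(-c3ccccc3)c3n(c1-2)[B-](F)(F)[N+]1=C(c2ccc(C)cc2)C(I)=C(c2ccccc2)C1=N3`) carries methyl in place of methoxy on an aromatic carbon so that 4-methoxyphenyl becomes 4-methylphenyl. Among the compounds with values here, no measured step gives a size for this change, so no shift beyond the scatter is expected in this assay and the estimate is a step that the limit leaves unreadable from compound 2 to compound 3 as an expected step. Compound 3 is expected near 60000 nM with an estimated range from 30000 nM to 120000 nM and will probably be reported only as a limit.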

Compound 3, half-maximal inhibitory concentration: > 50000 nM
Compound 3 ended at the assay's limit; the forecaster's own chance of this, stated with the estimate: 85%; the middle value is on the limit's open side.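

No new step can be read between compound 3 and compound 1 or compound 2 in this assay, as all three stand at a limit and not at a number: the limit of > 50000 nM in this assay, at which 3 of the 3 values shown sit. The compounds shown leave open whether methyl in place of methoxy, or iodo in place of bromo, changes the cytotoxicity at all.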